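Cytotoxicity notes: three ureas on a shared core, one pending

The source may hold more compounds than are shown below. What is called first, only, known or untested is meant among the compounds shown, and "the series" means these compounds.

Measured so far:
Compound 1 `Cc1cc(NC(=O)Nc2ccccc2N)c2ccccc2n1` — in an ADME assay on HEK293 cells (Homo sapiens) for cytotoxicity, with a stated time of 72 h (on this read-out lower numbers stand for an effect already at smaller amounts and higher numbers for an effect only at larger amounts of compound), compound 1 gives > 25000 nM, a limit of the assay and not a number.
Compound 2 `Cc1ccc(NC(=O)Nc2cc(C)nc3ccccc23)cc1` — compound 2 gives > 25000 nM, again a limit, not a number.
Compound 3 `Cc1cc(NC(=O)Nc2ccc(O)cc2)c2ccccc2n1` — compound 3 gives > 25000 nM, also a limit rather than a number.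

Compound 3 thus stands at the same limit as the other two; nothing separates the three on this read-out, because of the limit of > 25000 nM in this assay, at which 3 of the 3 values shown sit. The steps between them are unreadable for the same reason: a step that the two limits leave unreadable from compound 1 to compound 2, a step that the two limits leave unreadable from compound 1 to compound 3 and a step that the two limits leave unreadable from compound 2 to compound 3 all sit between two limits.

Compound 4 `Cc1cc(NC(=O)Nc2cccc(Cl)c2)c2ccccc2n1` is the next member. Its change from compound 3 is 3-chlorophenyl in place of 4-hydroxyphenyl on an amide-type nitrogen. The three measured steps bear on it only as far as they show that swapping the aryl group on the amide-type nitrogen has so far not pulled any compound below the limit. No directional size can be read from them, so no step beyond the scatter is expected; compound 4 is expected to give 40000 nM, in the range 15000 nM to 100000 nM, a step that the limit leaves unreadable from compound 3 to compound 4 that is itself only an estimate and most likely to be reported as a limit again.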

Compound 4, half-maximal effective concentration: 21000 nM
Compound 4: middle estimate off by 1.9-fold (0.28 log units), on the high side, within the range that was stated.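

Within the data shown here, compound 4 is the first member of the series to give a number rather than a limit in this assay, so 3-chlorophenyl on the amide-type nitrogen yields a reading that the three earlier aryl groups did not. Set against the earlier compounds, the change gives an at least 1.1-fold lower number from compound 3 to compound 4 (0.07 log units; that floor lies within the scatter), an at least 1.1-fold lower number from compound 2 to compound 4 (0.07 log units; that floor lies within the scatter) and an at least 1.1-fold lower number from compound 1 to compound 4 (0.07 log units; that floor lies within the scatter). These steps remain floors and none establishes a change beyond the scatter, because the other three compounds give only a limit: the limit of > 25000 nM in this assay, at which 3 of the 4 values shown sit.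

Going by these compounds, the true size of each step remains open, as does whether this reading depends on the chlorine itself or on where it sits on the ring. On these data alone, the response to a carboxylic acid on the phenyl ring, or to a longer alkyl chain in place of the aryl group, also remains open.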